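A Nitro Group Replaces Hydrogen in a Cytotoxicity Series

A few compounds are considered here, and "the series" means these few. Any claim that something is new, unique, unknown or untested is made for them only; others in the source may bear on it.

Compound 2 `Cc1ccc(C2=NN(c3nc(-c4ccccc4)cs3)C(c3ccc(F)cc3)C2)s1` was tested in an ADME assay on NIH3T3 cells (Mus musculus) for cytotoxicity, read by XTT assay, with a stated time of 24 h; a lower number here means a stronger inhibitor, a higher number a weaker inhibitor. In this assay compound 2 gives > 500 ug/mL, which is a limit of the assay rather than a number. Its closest relative, compound 1 `Cc1ccc(C2=NN(c3nc(-c4ccc(F)cc4)cs3)C(c3ccc(F)cc3)C2)s1`, differs from it in a single position. In this assay compound 1 gives > 500 ug/mL, again a limit. The step that the two limits leave unreadable from compound 1 to compound 2 therefore cannot be read, because both ends sit at the limit of > 500 ug/mL in this assay, at which 2 of the 2 values shown sit.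

Compound 3 `Cc1ccc(C2=NN(c3nc(-c4ccc([N+](=O)[O-])cc4)cs3)C(c3ccc(F)cc3)C2)s1` is the untested member. The change from compound 2 to compound 3 is nitro in place of hydrogen on an aromatic carbon. Among the measured compounds shown here, only one measured step touches this position of the shared core, and that step is unreadable, so the measured pair gives no guide to how far a change here moves the read-out. Because both measured compounds sit at the limit of > 500 ug/mL in this assay, at which 2 of the 2 values shown sit, the most likely outcome is that compound 3 also returns only a limit. The step of a number no higher from compound 2 to compound 3 (the limit leaves the size open) is therefore expected to be none beyond the scatter. Compound 3 is expected to give about 500 ug/mL, with a range from 200 ug/mL to 1000 ug/mL.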

Compound 3, half-maximal inhibitory concentration: 15.6 ug/mL
Estimate against measurement, compound 3: 32-fold (1.51 log units) above, and the stated range ends above it.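

In this assay, nitro in place of hydrogen on this aromatic carbon gives an at least 32-fold lower number from compound 2 to compound 3 (1.50 log units; beyond the scatter), and nitro in place of fluoro at the same place gives an at least 32-fold lower number from compound 1 to compound 3 (1.50 log units; beyond the scatter). Among the compounds shown here, the earlier step from fluoro to hydrogen cannot be read, so these two steps are the first measured sign that a change on this carbon can move the read-out, and by a large amount. Compound 3 is also the only one of the three compounds that gives a real number rather than a limit: the limit of > 500 ug/mL in this assay, at which 2 of the 3 values shown sit.

The compounds shown leave open whether this drop belongs to nitro alone, or whether another group on the same carbon, such as an amine, a carboxylic acid or a nitrile, would also bring the number down from the limit. As far as these compounds go, what nitro would do on another carbon of this ring also stays open, so a single nitro compound supports no wider pattern across the series.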